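Swapping the Aryl Group on Compound 1

The compounds below may be only part of what the source reports. "The series", "measured", "known", "first", "only" and "open" are said of these compounds alone.

In an ADME assay on PA-1 cells (Homo sapiens) for cytotoxicity, read by MTT assay, with a stated time of 72 h (on this read-out lower numbers stand for stronger inhibition and higher numbers for weaker inhibition), compound 1 (`COc1ccc(OC)c(C2=C(c3cc(OC)c(OC)c(OC)c3)C(=O)CC2O[SiH2]C(C)(C)C)c1`) gives 17 ug/mL, the higher of the two actual numbers. Compound 2 (`COc1ccc(C2=C(c3cc(OC)c(OC)c(OC)c3)C(=O)C(O[SiH2]C(C)(C)C)C2)cc1`) gives 7 ug/mL. Compound 3 (`COc1ccc(OC)c(C2=C(c3cc(OC)c(OC)c(OC)c3)C(=O)CC2O)c1`) reaches only a limit of the assay, > 100 ug/mL. Hydrogen replacing the silicon-bearing group gave an at least 5.8-fold higher number from compound 1 to compound 3 (0.76 log units; beyond the scatter), a size bounded by the limit of > 100 ug/mL in this assay, at which 1 of the 3 values shown sits. Compound 4 (`COc1ccc(C2=C(c3cc(OC)c(OC)c(OC)c3)C(=O)CC2O[SiH2]C(C)(C)C)cc1O`) keeps that group but has 3-hydroxy-4-methoxyphenyl in place of 2,5-dimethoxyphenyl on a double-bonded ring carbon. Going by the values given here, no measured step covers this swap, so the estimate stays anchored on compound 1 at 17 ug/mL. In this assay, the expected result is a 1.4-fold lower number from compound 1 to compound 4 (0.15 log units; within the scatter), none beyond the scatter. For compound 4 the estimated value is 12 ug/mL, within a range of 4 ug/mL to 40 ug/mL.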

Compound 4, half-maximal inhibitory concentration: 14 ug/mL
The estimate for compound 4 lay 1.2-fold (0.07 log units) below the measured number; measured number inside the range.
By their numbers in this assay, from the lowest: compounds 2, 4 and 1 (each within the scatter of the next, the first and the last beyond it). At a limit, above all of these: compound 3.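

In this assay, the step with 3-hydroxy-4-methoxyphenyl in place of 2,5-dimethoxyphenyl on a double-bonded ring carbon reads a 1.2-fold lower number from compound 1 to compound 4 (0.08 log units; within the scatter), so at this position the two aryl groups, one carrying a hydrogen-bond donor and the other none, are not told apart. The earlier single-place step concerned only the silicon-bearing group on the oxygen, not this aryl group. No measurement shown gives a reason for this result. Still open, on these data alone, is whether an amine or a carboxylic acid on this aryl ring would move the number beyond the scatter. Also open, as far as these compounds go, is how 3-hydroxy-4-methoxyphenyl behaves with a hydrogen replacing the silicon-bearing group.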